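A few compounds are considered here, and "the series" means these few. Any claim that something is new, unique, unknown or untested is made for them only; others in the source may bear on it.

Compound 2 `OC[C@@]12C[C@@H]1[C@@H](n1cnc3c(NC(C4CCC4)C4CCC4)nc(Cl)nc31)[C@H](O)[C@@H]2O` gives 28000 nM in an ADME assay on Vero 76 cells (Chlorocebus sabaeus) for cytotoxicity, read by neutral red uptake (a lower number here means that less compound is tolerated, a higher number that more compound is tolerated), and stands level with compound 3 `OC[C@H]1O[C@@H](n2cnc3c(NC(C4CCC4)C4CCC4)nc(Cl)nc32)[C@H](O)[C@@H]1O`, which gives 27000 nM; the step between them a 1.0-fold lower number from compound 2 to compound 3 (0.02 log units; within the scatter) touches only the sugar-like part. For compound 1 `CC(C)C(Nc1nc(Cl)nc2c1ncn2[C@H]1[C@H](O)[C@H](O)[C@]2(CO)C[C@H]12)C(C)C` this assay reports only a limit, > 100000 nM, not a number (the limit of > 100000 nM in this assay, at which 1 of the 3 values shown sits). Compound 4 `CC(C)(C)[C@H](Nc1nc(Cl)nc2c1ncn2[C@H]1[C@H](O)[C@H](O)[C@]2(CO)C[C@H]12)C1CC1` differs from compound 2 in the group on the ring nitrogen: 1-cyclopropyl-2,2-dimethylpropyl in place of dicyclobutylmethyl on a nitrogen on an aromatic ring. The step that bears on it is the earlier change at the same nitrogen, an at least 3.5-fold lower number from compound 1 to compound 2 (0.55 log units; beyond the scatter), where a more compact dicyclobutylmethyl went with a clearly lower number. Compound 4 carries a group part-way between those two, so compound 4 is expected to give 45000 nM, with a range from 20000 nM to 100000 nM. The expected step, a 1.6-fold higher number from compound 2 to compound 4 (0.21 log units; within the scatter), is at most modest.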

Compound 4, half-maximal cytotoxic concentration: > 100000 nM
Compound 4 gave a limit, no number (the forecaster's own chance of this, stated with the estimate: 30%); middle value at least 2.2-fold (0.34 log units) from the limit.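

The change is an at least 3.5-fold higher number from compound 2 to compound 4 (0.55 log units; beyond the scatter), so in this assay dicyclobutylmethyl now stands apart from two different groups on this nitrogen, not just from 1-isopropyl-2-methylpropyl. Compound 4 gives a limit, not a number, as compound 1 does: the limit of > 100000 nM in this assay, at which 2 of the 4 values shown sit.

The step between these two compounds cannot be read, since both values are limits. The compounds shown leave open whether a group carrying an amine, or a straight pentyl chain, on this nitrogen would also reach this limit. They also leave open how 1-cyclopropyl-2,2-dimethylpropyl would behave with the sugar-like part of compound 3.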